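The compounds below may be only part of what the source reports. "The series", "measured", "known", "first", "only" and "open" are said of these compounds alone.

Measured compounds:
Compound 1, `FC(F)(F)c1cc(NC[C@H]2CCCN2)c2cn[nH]c2c1`: 9580 nM in an assay for inhibition of Indoleamine 2,3-dioxygenase 1 (Homo sapiens), with stated times of 10 min and 60 min; a higher number here means a weaker inhibitor, a lower number a stronger inhibitor
Compound 2, `O=C1NC(=O)c2c(NCc3ccccc3[N+](=O)[O-])cccc21`: only a limit, > 100000 nM, in this assay

Going by the values given here, compound 1 carries the only real number in this assay among the two measured compounds. The other value belongs to compound 2, and it is the limit of > 100000 nM in this assay, at which 1 of the 2 values shown sits, rather than a measured number, so nothing can be said about how far apart the two compounds lie or in which order they stand. Among the compounds with values here, no pair of measured compounds differs in a single place, so no measured step exists to lean on.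

Compound 3, `FC(F)(F)c1cc(NCc2cccc(Br)c2)c2cn[nH]c2c1`, differs from compound 1 in one place: 3-bromophenyl in place of pyrrolidin-2-yl on a saturated chain carbon bound to a nitrogen on an aromatic ring. The chain and the nitrogen on the aromatic ring are kept; only the group at the end of the chain is exchanged.

Within the data shown here, with no measured step to guide the size of this change, the expectation for compound 3 is a modest shift, expected to be a 1.9-fold lower number from compound 1 to compound 3 (0.28 log units; within the scatter) in this assay, which sits near the edge of the usual scatter. Compound 3 is therefore estimated at 5000 nM, with a likely range from 1000 nM to 30000 nM.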

Compound 3, half-maximal inhibitory concentration: > 100000 nM
Compound 3 ended at the assay's limit; the forecaster's own chance of this, stated with the estimate: 10%; middle value at least 20-fold (1.30 log units) away from the limit.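

Going by these compounds alone, exchanging pyrrolidin-2-yl for 3-bromophenyl on a saturated chain carbon bound to a nitrogen on an aromatic ring gives the only measured single-place step here, an at least 10-fold higher number from compound 1 to compound 3 (1.01 log units; beyond the scatter) in this assay, so the group at the end of the chain matters a great deal, and the core and chain kept in compound 3 do not secure a measurable value on their own. In this assay compound 3 gives > 100000 nM, which is a limit and not a number. The printed step therefore marks only the smallest change that fits the data, and the weak end of this small set stays unresolved, with a real number for compound 1 alone: the limit of > 100000 nM in this assay, at which 2 of the 3 values shown sit.

The compounds shown leave open which part of pyrrolidin-2-yl counts, whether its ring, its nitrogen or its defined stereocentre, since the 3-bromophenyl group differs from it in all of these at once. Also open, from the compounds shown here alone, is whether a simple open-chain amine such as dimethylamino, or a plain phenyl ring without the bromine, at the end of the chain would sit nearer to compound 1 or to compound 3.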